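Trifluoromethylcarbonyl in place of hydrogen on the core

The source may report more compounds than this note shows. Statements on the series, on what has been measured and on what is new or still open speak of the compounds shown alone.

Compound 2 `CN(C)CC[C@H](CSc1ccccc1)Nc1ccc(S(=O)(=O)NC(=O)c2ccc(N3CCN(Cc4ccccc4-c4ccc(Cl)cc4)CC3)cc2)cc1` is the reference here. In an assay on isolated protein for displacement of a labelled ligand from Apoptosis regulator Bcl-2 (Homo sapiens), read by fluorescence polarization (a higher number here means a weaker inhibitor, a lower number a stronger inhibitor), compound 2 gives < 1 nM, which is a limit of the assay and not a number. Compound 1 `CN(C)CC[C@H](CSc1ccccc1)Nc1ccc(S(=O)(=O)NC(=O)c2ccc(N3CCN(Cc4ccccc4-c4ccc(Cl)cc4)CC3)cc2)cc1S(C)(=O)=O` carries a methylsulfonyl on the same aromatic carbon that is bare in compound 2. In this assay compound 1 gives < 1 nM, again a limit rather than a number. Compound 3 `CN(C)CC[C@H](CSc1ccccc1)Nc1ccc(S(=O)(=O)NC(=O)c2ccc(N3CCN(CC4=C(c5ccc(Cl)cc5)CCCC4)CC3)cc2)cc1[N+](=O)[O-]` differs at more than one place and has a nitro at that position. In this assay compound 3 gives < 1 nM, also a limit. Compound 2 therefore stands at the same limit as the other two, and the limit of < 1 nM in this assay, at which 3 of the 3 values shown sit, fixes where the whole set sits.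

Compound 4 `CN(C)CC[C@H](CSc1ccccc1)Nc1ccc(S(=O)(=O)NC(=O)c2ccc(N3CCN(Cc4ccccc4-c4ccc(Cl)cc4)CC3)cc2)cc1C(=O)C(F)(F)F` is not yet measured. The change from compound 2 is (trifluoromethyl)carbonyl in place of hydrogen on an aromatic carbon. Among the measured compounds shown here, the one measured step that touches this carbon is a step that the two limits leave unreadable from compound 1 to compound 2; it cannot be read, and compound 3 adds only a further limit at that position. For the measured compounds named here, no measured step gives a size to work from, so the change from compound 2 to compound 4 is expected to leave the value at the limit, with a step that the limit leaves unreadable from compound 2 to compound 4. Compound 4 is thus expected to give 0.5 nM, in the range 0.1 nM to 2 nM.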

Compound 4, inhibition constant: < 1 nM
Compound 4: only a limit was reported; the forecaster's own chance of this, stated with the estimate: 80%; the middle value is on the limit's open side.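

In this assay compound 4 gives < 1 nM, a limit of the assay and not a number. The steps from compound 2 and compound 1 to compound 4 therefore cannot be read: the limit of < 1 nM in this assay, at which 4 of the 4 values shown sit. The compounds shown leave open whether hydrogen, methylsulfonyl and (trifluoromethyl)carbonyl on this aromatic carbon differ at all in this assay.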